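A few compounds are considered here, and "the series" means these few. Any claim that something is new, unique, unknown or untested is made for them only; others in the source may bear on it.

Measured so far:
compound 1 `Cc1nccnc1C1CN2CCC1CC2`: 4%
compound 2 `Clc1nccnc1C1CN2CCC1CC2`: 13%

In a functional assay on A9L-m1 cells with A9 (Mus musculus) as the target (on this read-out higher numbers stand for larger maximal responses and lower numbers for smaller maximal responses), compound 1 gives 4%, the lowest of the two numbers seen; the nearest is compound 2, and the step of a number 9 percentage points higher from compound 1 to compound 2 (within the scatter) shows that the two lie together. The unmeasured compound 3 `CCCCSc1nccnc1C1CN2CCC1CC2` differs from compound 1 in one place: butylsulfanyl in place of methyl on an aromatic carbon. Among the measured compounds shown here, the only measured step at that same place is the one from methyl to chloro, a number 9 percentage points higher from compound 1 to compound 2 (within the scatter), and it did not leave the scatter. Nothing measured speaks for butylsulfanyl at this place, so the expectation rests on the two small values seen. Compound 3 is therefore expected to stay in the same low region, with a step estimated as a number 8 percentage points higher from compound 1 to compound 3 (within the scatter), not clearly beyond the scatter in either direction. Compound 3 is estimated at 12%, with a range from 0% to 35%.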

Compound 3, largest response reached (reported as maximum), in percent of the reference or control that the assay uses: 5%
Estimate against measurement, compound 3: 7 percentage points above; the range from low to high includes it.
By their numbers in this assay, from the lowest: compounds 1, 3 and 2 (each within the scatter of the next).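

With butylsulfanyl at this place, this assay shows a number 1 percentage points higher from compound 1 to compound 3 (within the scatter) and a number 8 percentage points lower from compound 2 to compound 3 (within the scatter) and so neither step leaves the scatter. The position on an aromatic carbon next to the ring nitrogen has now carried methyl, chloro and butylsulfanyl, and all three compounds lie together at small maximal responses. Going from 1 heavy atom in methyl to 5 in butylsulfanyl therefore gave no step beyond the scatter, which the pair with methyl and chloro alone could not show. From the compounds shown here alone, whether an amine, a carboxylic acid or a butoxy chain at this place would lift the response clear of the scatter stays open. So does the effect of a chain longer than butylsulfanyl, and no measurement at hand accounts for these small values.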